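Bromo for chloro across two related cores: tolerance notes

The source may report more compounds than this note shows. Statements on the series, on what has been measured and on what is new or still open speak of the compounds shown alone.

Among the measured compounds shown here, compound 1 `C#C[C@]1(CO)O[C@@H](n2cc(Cl)c(=O)[nH]c2=O)C[C@@H]1O` is the only member of the set with a numerical reading: in a functional assay on MT4 cells (Homo sapiens), read by MTT assay (a lower number here means that less compound is tolerated, a higher number that more compound is tolerated), compound 1 gives 81700 nM. Compound 2 `C#C[C@]1(CO)O[C@@H](n2cc(Br)c(=O)[nH]c2=O)C[C@@H]1O` differs from it by bromo in place of chloro on an aromatic carbon. In this assay compound 2 reaches only a limit, > 100000 nM. The measured step is an at least 1.2-fold higher number from compound 1 to compound 2 (0.08 log units; that floor lies within the scatter).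

Compound 3 `C#C[C@]1(CO)O[C@@H](n2cc(Cl)c(N)nc2=O)C[C@@H]1O` carries a different core; the difference between the two cores is not broken down here. In this assay compound 3 likewise sits at a limit, > 100000 nM. Two of the three readings rest on (the limit of > 100000 nM in this assay, at which 2 of the 3 values shown sit).

Compound 4 `C#C[C@]1(CO)O[C@@H](n2cc(Br)c(N)nc2=O)C[C@@H]1O` differs from compound 3 by bromo in place of chloro on an aromatic carbon. This is the same kind of change as from compound 1 to compound 2, the surroundings differing only in that the position is ortho to an amino group (1 heavy atom) rather than ortho to a group of 1 heavy atom.

The expected step from compound 3 to compound 4 is a step that the limit leaves unreadable from compound 3 to compound 4, resting on an at least 1.2-fold higher number from compound 1 to compound 2 (0.08 log units; that floor lies within the scatter) and on (the limit of > 100000 nM in this assay, at which 2 of the 3 values shown sit). Compound 4 is expected to give 150000 nM in this assay, within a range from 90000 nM to 300000 nM.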

Compound 4, half-maximal cytotoxic concentration: > 100000 nM
Compound 4 ended at the assay's limit (the forecaster's own chance of this, stated with the estimate: 80%); the middle value lies beyond the limit too.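

In this assay compound 4 sits at a limit, > 100000 nM, and compound 3 is also at a limit, so no step can be read from compound 3 to compound 4: the limit of > 100000 nM in this assay, at which 3 of the 4 values shown sit.

The compounds shown leave open how far beyond the limit compound 2, compound 3 and compound 4 lie in this assay, and whether bromo in place of chloro changes the reading on either core.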